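This account rests on a few compounds, and the source may have more. Where it says the series, first, only, none or still open, it means among the compounds named here.

Compound 3 `CC(C)CCNC(=O)C(C)NC(=O)C(C)CC(=O)[C@H](CC(C)C)NC(=O)C(NC(=O)CC(C)C)C(C)C` is the strongest inhibitor among the three compounds measured in an assay on isolated protein for inhibition of Pepsin A (Sus scrofa); a higher number here means a weaker inhibitor, a lower number a stronger inhibitor: compound 3 gives 27 nM. The two other compounds share its core and differ from it only at one saturated chain carbon. Compound 1 `CC(C)CCNC(=O)C(C)NC(=O)CCC(=O)[C@H](CC(C)C)NC(=O)C(NC(=O)CC(C)C)C(C)C`, which carries a hydrogen at that position, gives 2140 nM in this assay, and compound 2 `CC(C)CCNC(=O)C(C)NC(=O)[C@@H](CC(=O)[C@H](CC(C)C)NC(=O)C(NC(=O)CC(C)C)C(C)C)Cc1ccccc1`, which carries a benzyl group there, gives 850 nM. Both steps away from compound 1 lie beyond the scatter: a 2.5-fold lower number from compound 1 to compound 2 (0.40 log units; beyond the scatter) and a 79-fold lower number from compound 1 to compound 3 (1.90 log units; beyond the scatter). Compound 4 `CC(C)CCNC(=O)C(C)NC(=O)C(CC(=O)[C@H](CC(C)C)NC(=O)C(NC(=O)CC(C)C)C(C)C)Cc1ccccc1` has not yet been measured. It differs from compound 3 by phenyl in place of hydrogen on a saturated chain carbon, two bonds along the chain from a carbonyl carbon. Among the measured compounds shown here, no measured step repeats this change exactly; the nearest comparison is compound 2 against compound 3, which differ in the same way except that compound 2 has one fixed spatial arrangement at that carbon while compound 4 leaves it open. Compound 2 gives a clearly higher number than compound 3 in this assay, so the phenyl addition is expected to weaken inhibition. The step of a 31-fold higher number from compound 3 to compound 4 (1.50 log units; beyond the scatter) is therefore expected. Compound 4 is estimated to give 850 nM in this assay, within a range from 300 nM to 2400 nM.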

Compound 4, inhibition constant: 72 nM
For compound 4 the middle estimate is 12-fold (1.07 log units) above the measured one; measured number outside the range, below it.
By their numbers in this assay, from the lowest: compound 3; then compound 4; then compound 2; then compound 1.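

In this assay, extending the methyl to a benzyl costs only a modest amount of inhibition, with a 2.7-fold higher number from compound 3 to compound 4 (0.43 log units; beyond the scatter), far less than compound 2 alone had suggested. A benzyl group at this position can therefore keep most of the gain seen with methyl, as shown by a 30-fold lower number from compound 1 to compound 4 (1.47 log units; beyond the scatter), whereas the R-drawn benzyl compound shows only a 2.5-fold lower number from compound 1 to compound 2 (0.40 log units; beyond the scatter). The step of a 12-fold lower number from compound 2 to compound 4 (1.07 log units; beyond the scatter) is large even though the two compounds share the same atoms and bonds, so the spatial arrangement at this carbon, and not the benzyl group alone, appears to matter, and the one structural difference that can account for the step is: the fact that one of compounds 2 and 4 is drawn with a defined configuration and the other without, at the place where they differ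

Still open is which spatial arrangement at this carbon lies behind the low numbers of compound 3 and compound 4, as both are drawn without a configuration there, so a single arrangement might give a lower or a higher number than either drawing shows. Also open, on these data alone, is how an ethyl group, a longer chain or an amine at this carbon would compare with methyl and benzyl.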